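Trimming a Bulky Group Down to Methyl

The source may report more compounds than this note shows. Statements on the series, on what has been measured and on what is new or still open speak of the compounds shown alone.

Of the compounds shown here, two sharing one core have been tested in an assay on membranes from Jurkat cells for displacement of a labelled ligand from Sigma intracellular receptor 2 (Homo sapiens), read by scintillation counting, with a stated time of 1 h; on this read-out higher numbers stand for weaker inhibition and lower numbers for stronger inhibition. Compound 1 `Cn1nc(CN2CCCC2)nc1-c1ccc(C2(C(F)(F)F)CC2)cc1` gives only a limit of the assay, > 1000 nM; this is the limit of > 1000 nM in this assay, at which 1 of the 2 values shown sits. Compound 2 `Cn1nc(CN2CCCC2)nc1-c1cccc(C(C)(C)C)c1` gives 1000 nM in this assay. Compound 3 `Cc1ccc(-c2nc(CN3CCCC3)nn2C)cc1` has not yet been measured; it differs from compound 1 by methyl in place of 1-(trifluoromethyl)cyclopropyl on an aromatic carbon. For the measured compounds named here, no measured step sets a precedent for this change, and the starting point is itself only a limit, so the direction cannot be read off the data. The expectation is that compound 3 lands near the weak end seen so far, with the step that the limit leaves unreadable from compound 1 to compound 3 expected to stay within the scatter. Compound 3 is therefore estimated at 1500 nM, most likely between 300 nM and 8000 nM.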

Compound 3, inhibition constant: > 1000 nM
Compound 3: no number, only a limit; the forecaster's own chance of this, stated with the estimate: 50%; the middle value does not contradict the limit.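

For the compounds shown here, compound 1 and compound 3 each give only a limit in this assay, not a number, so no step between them can be read: the limit of > 1000 nM in this assay, at which 2 of the 3 values shown sit. The compounds shown leave open whether methyl in place of 1-(trifluoromethyl)cyclopropyl strengthens, weakens or leaves unchanged the inhibition.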